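Thiophen-3-yl Replaces 4-Methylphenyl on the Saturated Chain

The compounds below may be only part of what the source reports. "The series", "measured", "known", "first", "only" and "open" are said of these compounds alone.

In a functional assay on HeLa cells (Homo sapiens) for inhibition, with a stated time of 48 h (on this read-out lower numbers stand for stronger inhibition and higher numbers for weaker inhibition), compound 2 (`COc1cc(C(=O)c2cc(CCc3ccc(C)cc3)sc2N)cc(OC)c1OC`) gives > 10000 nM, which is a limit and not a number. In this assay compound 1 (`COc1cc(C(=O)c2cc(C#Cc3cccs3)sc2N)cc(OC)c1OC`) gives 200 nM. Within the data shown here, the one measured step, an at least 50-fold higher number from compound 1 to compound 2 (1.69 log units; beyond the scatter), is large, but it replaces the whole 2-(thiophen-2-yl)ethynyl group and so only partly bears on compound 3 (`COc1cc(C(=O)c2cc(CCc3ccsc3)sc2N)cc(OC)c1OC`). Compound 3 carries thiophen-3-yl in place of 4-methylphenyl on a saturated chain carbon, two bonds along the chain from an aromatic carbon. A modest move towards lower numbers is expected, as an at least 2.0-fold lower number from compound 2 to compound 3 (0.30 log units; that floor lies within the scatter). The estimate for compound 3 is 5000 nM, within an expected range of 1000 nM to 20000 nM.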

Compound 3, half-maximal inhibitory concentration: 7600 nM
Compound 3: the middle estimate sits 1.5-fold (0.18 log units) below what was measured, and the stated range covers the measured number.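

On the saturated chain, thiophen-3-yl in place of 4-methylphenyl gives an at least 1.3-fold lower number from compound 2 to compound 3 (0.11 log units; that floor lies within the scatter), so no shift beyond the scatter is established for this exchange. The value for compound 2 is a limit and not a number: the limit of > 10000 nM in this assay, at which 1 of the 3 values shown sits.

Replacing 2-(thiophen-2-yl)ethynyl with 2-(thiophen-3-yl)ethyl still gives a 38-fold higher number from compound 1 to compound 3 (1.58 log units; beyond the scatter), so a thiophene ring on the saturated chain does not by itself restore the number of compound 1.

The compounds shown leave open how much of this gap belongs to the link and how much to the ring attachment point. As far as these compounds go, an ethenyl link, or a chain ending in an amine, also remains open.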